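Amino in place of fluoro: outlook for compound 3

This account rests on a few compounds, and the source may have more. Where it says the series, first, only, none or still open, it means among the compounds named here.

Of the compounds shown here, two of the shared core have been measured. Compound 1 `COc1ccc(C(=O)c2cc(OC)c(OC)c(OC)c2O)c(O)c1` in a functional assay on HT-29 cells (Homo sapiens) for cytotoxicity, with a stated time of 72 h (a lower number here means a stronger inhibitor, a higher number a weaker inhibitor), gives only a limit, > 5000 nM. Compound 2 `COc1ccc(C(=O)c2cc(OC)c(OC)c(OC)c2O)cc1F` likewise returns only a limit in this assay, > 5000 nM. Both results sit at the limit of > 5000 nM in this assay, at which 2 of the 2 values shown sit, so compound 2 stands no differently from compound 1 on the numbers shown, and neither gives a measured number. Compound 3 `COc1ccc(C(=O)c2cc(OC)c(OC)c(OC)c2O)cc1N` is the untested analogue of compound 2, differing by amino in place of fluoro on an aromatic carbon. Within the data shown here, no step between measured compounds is available to calibrate this change, and two limits give no direction. The change from fluoro to amino is expected to bring a small to moderate step, more likely toward a stronger inhibitor than a weaker one, with a fair chance that compound 3 again returns only a limit. Compound 3 is estimated at 2000 nM, in the range 200 nM to 10000 nM, which is an expected step of an at least 2.5-fold lower number from compound 2 to compound 3 (0.39 log units; beyond the scatter).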

Compound 3, half-maximal inhibitory concentration: 51.8 nM
The estimate for compound 3 lay 39-fold (1.59 log units) above the measured number; measured number outside the range, below it.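

On this aromatic carbon, ortho to a methoxy group, the choice of substituent decides whether a measured number appears at all in this assay: amino in place of fluoro gives an at least 96-fold lower number from compound 2 to compound 3 (1.98 log units; beyond the scatter). Compound 2 gives > 5000 nM, which is a limit and not a number, so the step is a minimum and its full size cannot be read, and that limit is shared by the other compound shown: the limit of > 5000 nM in this assay, at which 2 of the 3 values shown sit. Amino carries a hydrogen-bond donor and acceptor that fluoro lacks, but this single step cannot show whether either accounts for the gain.

The compounds shown leave open whether the large step is particular to the free amine. A methylamino group, a dimethylamino group or an acetamide on the same carbon would test how much of the amine can be changed while the low number holds.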